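This account rests on a few compounds, and the source may have more. Where it says the series, first, only, none or still open, it means among the compounds named here.

Measured so far in a functional assay for activation of Alpha-1A adrenergic receptor (Homo sapiens), read by calcium flux; on this read-out higher numbers stand for an effect only at larger amounts of compound and lower numbers for an effect already at smaller amounts:
- compound 1 `c1cncc(-c2ccccc2OCC2=NCCN2)c1`: 2 nM
- compound 2 `c1c[nH]c(-c2ccccc2OCC2=NCCN2)c1`: 1.26 nM
- compound 3 `Cc1ccc(-c2ccccc2OCC2=NCCN2)s1`: 25.1 nM

Compound 1 stands second highest of the three numbers. Its nearest neighbour is compound 2, reached by a 1.6-fold lower number from compound 1 to compound 2 (0.20 log units; within the scatter); its furthest is compound 3, reached by a 13-fold higher number from compound 1 to compound 3 (1.10 log units; beyond the scatter). Compound 2 and compound 3 are separated by a 20-fold higher number from compound 2 to compound 3 (1.30 log units; beyond the scatter).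

Compound 4 `Cn1nccc1-c1ccccc1OCC1=NCCN1` is not yet measured. Its change from compound 1 is 1-methyl-1H-pyrazol-5-yl in place of pyridin-3-yl on an aromatic carbon.

Among the measured compounds shown here, two measured steps bear on this change, both replacing pyridin-3-yl with a five-membered ring on the same aromatic carbon. The step to compound 2 (1H-pyrrol-2-yl) stayed within the scatter, whereas the step to compound 3 (5-methylthiophen-2-yl) went to a much higher number. The 1-methyl-1H-pyrazol-5-yl group of compound 4 shares the five-membered ring with both and a methyl with compound 3 only. A moderate rise in the number is therefore expected, short of what compound 3 showed and plausibly not far beyond the scatter: the expected step is a 3.0-fold higher number from compound 1 to compound 4 (0.48 log units; beyond the scatter). Compound 4 is estimated at 6 nM in this assay, within a range from 1.5 nM to 25 nM.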

Compound 4, half-maximal effective concentration: 39.8 nM
Compound 4: middle estimate off by 6.6-fold (0.82 log units), on the low side, and the stated range ends below it.
By their numbers in this assay, from the lowest: compounds 2 and 1 (each within the scatter of the next); then compounds 3 and 4 (each within the scatter of the next).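

In this assay the 1-methyl-1H-pyrazol-5-yl group does not behave like the 1H-pyrrol-2-yl group at this aromatic carbon: the replacement of pyridin-3-yl gives a 20-fold higher number from compound 1 to compound 4 (1.30 log units; beyond the scatter), and the comparison with the pyrrole gives a 32-fold higher number from compound 2 to compound 4 (1.50 log units; beyond the scatter). The step of a 1.6-fold higher number from compound 3 to compound 4 (0.20 log units; within the scatter) lies within the scatter, so the two methyl-bearing five-membered rings cannot be told apart here, and a five-membered aromatic ring as such does not keep the low number of compound 2. Among the listed compounds, both groups carrying a methyl give large rises from compound 1, but no measurement available here accounts for this.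

The compounds shown do not separate the methyl from the ring itself, since each methyl-bearing group also differs in its ring atoms. Going by these compounds, how an unsubstituted pyrazole, or a methoxy group or an amine in the methyl's place, would read at this position remains open.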